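Ureas on the shared core: removing one methyl

The source may report more compounds than this note shows. Statements on the series, on what has been measured and on what is new or still open speak of the compounds shown alone.

Measured so far:
compound 1 `CCNC(=O)Nc1ccc(C(C)CC)cc1` — 43000 nM
compound 2 `CCNC(=O)Nc1ccc(C(C)(C)C)cc1` — 16000 nM; 70 nM (2 entries)
compound 3 `CCCNC(=O)Nc1ccc(C(C)CC)cc1` — 30000 nM

In a functional assay on L1210 cells (Mus musculus) (on this read-out lower numbers stand for stronger inhibition and higher numbers for weaker inhibition), compound 3 gives the lowest of the two single numbers, and compound 1 sits within the scatter of it, a 1.4-fold lower number from compound 1 to compound 3 (0.16 log units; within the scatter). Compound 2 has no single number: the several entries of compound 2 in this assay, 16000 nM; 70 nM (2 entries) shows entries far apart. Compound 4 `CCCNC(=O)Nc1ccc(C(C)C)cc1` differs from compound 3 by hydrogen in place of methyl on a saturated chain carbon, two bonds along the chain from an aromatic carbon. Going by the values given here, no measured step touches this part of the structure; the only measured step, a 1.4-fold lower number from compound 1 to compound 3 (0.16 log units; within the scatter), sits on the other chain and is within the scatter. Compound 1 and compound 2 also differ near this place, but the spread of the entries of compound 2 allows no usable comparison. The expected step is no change at the digits printed from compound 3 to compound 4 (within the scatter), within the scatter. Compound 4 is expected at 30000 nM, in a range of 8000 nM to 100000 nM.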

Compound 4, half-maximal inhibitory concentration: 14000 nM
Estimate against measurement, compound 4: 2.1-fold (0.33 log units) above, within the range that was stated.
By their numbers in this assay, from the lowest: compound 4; then compounds 3 and 1 (each within the scatter of the next).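

In this assay, going by these compounds alone, hydrogen in place of methyl on this chain gives a 2.1-fold lower number from compound 3 to compound 4 (0.33 log units; beyond the scatter), a modest change but the first step beyond the scatter. Going from sec-butyl to isopropyl therefore costs no inhibition, whereas the step on the other chain, a 1.4-fold lower number from compound 1 to compound 3 (0.16 log units; within the scatter), shows no readable change. Compound 2 adds no check on branching at this place: the several entries of compound 2 in this assay, 16000 nM; 70 nM (2 entries)

Still open, from the compounds shown here alone, is whether the number keeps falling with a shorter group here, such as ethyl or methyl, or rises with a longer chain. Also open, going by these compounds, is whether a hydroxyl or an amine at this place would be tolerated.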